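Adding a methyl to the isoxazole ring of a sulfonamide

The compounds below may be only part of what the source reports. "The series", "measured", "known", "first", "only" and "open" are said of these compounds alone.

Measured so far:
- compound 1, `N=C(N)NS(=O)(=O)c1ccc(N/C(S)=N\c2ccnc3cc(C(F)(F)F)ccc23)cc1`: 23900 nM
- compound 2, `Cc1cc(NS(=O)(=O)c2ccc(N/C(S)=N\c3ccnc4cc(C(F)(F)F)ccc34)cc2)on1`: 60200 nM

Both compounds share a core that carries a sulfonamide, and they differ only in the group on the sulfonamide nitrogen. In a functional assay on AS49-RAW cells (Homo sapiens) for antiproliferative activity, read by sulforhodamine B assay, with a stated time of 48 h (a lower number here means a stronger inhibitor, a higher number a weaker inhibitor), compound 1 gives 23900 nM, and compound 2 gives 60200 nM. The change a 2.5-fold higher number from compound 1 to compound 2 (0.40 log units; beyond the scatter), so compound 2 has the highest number of the two measured compounds, that is, it is the weaker of the pair.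

Compound 3, `Cc1noc(NS(=O)(=O)c2ccc(N/C(S)=N\c3ccnc4cc(C(F)(F)F)ccc34)cc2)c1C`, differs from compound 2 by methyl in place of hydrogen on an aromatic carbon of the five-membered ring, two ring bonds from the ring nitrogen and two ring bonds from the ring oxygen. Within the data shown here, no measured step touches this position; the single known step changes the whole group on the sulfonamide nitrogen, not a substituent on the ring. Without a precedent, the expectation for compound 3 is a step no larger than the usual scatter, in either direction, as a 1.0-fold lower number from compound 2 to compound 3 (0.00 log units; within the scatter). Compound 3 is therefore estimated at 60000 nM, with a range from 25000 nM to 150000 nM.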

Compound 3, half-maximal inhibitory concentration: 34000 nM
For compound 3 the middle estimate is 1.8-fold (0.25 log units) above the measured one; low and high end bracket the measured number.
By their numbers in this assay, from the lowest: compounds 1, 3 and 2 (each within the scatter of the next, the first and the last beyond it).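

In this assay, among these compounds, methyl in place of hydrogen on this aromatic carbon, the change from 3-methyl-1,2-oxazol-5-yl to 3,4-dimethyl-1,2-oxazol-5-yl, gives a 1.8-fold lower number from compound 2 to compound 3 (0.25 log units; within the scatter) and so offers a first reading at this position: a methyl here leaves the number within the normal spread of repeated measurements. Measured against the group on the sulfonamide nitrogen of compound 1, the dimethyl ring gives a 1.4-fold higher number from compound 1 to compound 3 (0.15 log units; within the scatter) while the monomethyl ring gave a 2.5-fold higher number from compound 1 to compound 2 (0.40 log units; beyond the scatter) but, as compound 2 and compound 3 cannot be told apart, this contrast is no sign that the methyl closes a real gap. Nothing measured here explains the result at this position.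

On these data alone, a single small group on a single carbon says little about the position as a whole, so it remains open whether an ethyl, an amine or a carboxylic acid on the same carbon would move the number beyond the scatter. As far as these compounds go, it is also open whether the same methyl would give a similar step with a different core.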